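This account rests on a few compounds, and the source may have more. Where it says the series, first, only, none or still open, it means among the compounds named here.

Compound 3, `CCCn1c(=O)n(CCO)c(=O)c2[nH]cnc21`, gives 50000 nM in an assay on Cerebral cortex for binding affinity to adenosine receptor A1 (Cavia porcellus), read by radioligand binding (a higher number here means a weaker inhibitor, a lower number a stronger inhibitor), which is the highest of the three numbers recorded so far. Compound 1, `CCCn1c(=O)n(CCC(N)=O)c(=O)c2[nH]cnc21`, gives 31500 nM in this assay, and compound 2, `CCCn1c(=O)n(CCN(C)C)c(=O)c2[nH]cnc21`, gives 4300 nM. The step of a 1.6-fold higher number from compound 1 to compound 3 (0.20 log units; within the scatter) lies within the scatter, whereas the step of a 12-fold higher number from compound 2 to compound 3 (1.07 log units; beyond the scatter) stands clearly beyond it, as does the step of a 7.3-fold lower number from compound 1 to compound 2 (0.86 log units; beyond the scatter). Compound 4, `CCCn1c(=O)n(CC(C)=O)c(=O)c2[nH]cnc21`, has not yet been measured. Its difference from compound 3 is acetyl in place of hydroxymethyl on a saturated chain carbon bound to an aromatic nitrogen. Going by the values given here, no measured step places a ketone on this chain, so the closest guide is the exchange of carbamoyl for hydroxy, which gave a 1.6-fold higher number from compound 1 to compound 3 (0.20 log units; within the scatter) and stayed within the scatter; the only change that moved the number beyond the scatter was the one bringing in dimethylamino, which compound 4 does not carry. Compound 4 is therefore expected to land near the numbers of compound 1 and compound 3, with at most a small step, a 1.7-fold lower number from compound 3 to compound 4 (0.22 log units; within the scatter), that may not exceed the scatter. The estimate for compound 4 in this assay is 30000 nM, with a range from 10000 nM to 90000 nM.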

Compound 4, inhibition constant: 11400 nM
For compound 4 the middle estimate is 2.6-fold (0.42 log units) above the measured one; low and high end bracket the measured number.
By their numbers in this assay, from the lowest: compound 2; then compound 4; then compounds 1 and 3 (each within the scatter of the next).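

In this assay the exchange of 2-hydroxyethyl for 2-oxopropyl gives a 4.4-fold lower number from compound 3 to compound 4 (0.64 log units; beyond the scatter) and so shows that this chain can move the number beyond the scatter without a dimethylamino group, which the earlier compounds had not shown. Acetyl also stands apart from carbamoylmethyl, with a 2.8-fold lower number from compound 1 to compound 4 (0.44 log units; beyond the scatter) as the step, even though compound 1 and compound 3 lie within the scatter of each other, so the groups at this place no longer fall into just one group with dimethylamino set apart. Dimethylamino nevertheless keeps the lowest number of the four, with a 2.7-fold higher number from compound 2 to compound 4 (0.42 log units; beyond the scatter) as its step to the ketone, and acetyl, with 0 hydrogen-bond donors where hydroxymethyl has 1, sits between these extremes.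

Nothing measured here accounts for the order of these groups. As far as these compounds go, it remains open how a carboxylic acid, a primary amine or a longer chain ending in a ketone would compare at this place, and whether the ketone's step would hold with a group other than the propyl chain on the other ring nitrogen.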